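The compounds below may be only part of what the source reports. "The series", "measured", "known", "first", "only" and "open" are said of these compounds alone.

Measured in a physicochemical assay for solubility, at pH 1.1; on this read-out lower numbers stand for lower solubility and higher numbers for higher solubility:

- compound 1 `CCCN(Cc1ccc(OCCn2c(=O)ccn(C)c2=O)c(C)c1)C(CC(=O)O)c1ccc(Cl)cc1`: 3000000 nM
- compound 2 `CCCN(Cc1ccc(OCCn2c(=O)ccn(C)c2=O)c(OC)c1)C(CC(=O)O)c1ccc(Cl)cc1`: 3000000 nM
- compound 3 `COc1cc(CN(CC2CC2)C(CC(=O)O)c2ccc(Cl)cc2)ccc1OCCn1c(=O)ccn(C)c1=O`: 3000000 nM

Among these three, compound 2 gives 3000000 nM, level with the other two compounds at the digits shown. The next compound to be measured, compound 4 `CCCN(Cc1ccc(OCCn2c(=O)ccn(C)c2=O)c(OC)c1)C(CC(=O)O)c1ccc2c(c1)CCO2`, differs from compound 2 in one place: a group of 9 heavy atoms (8 carbon, 1 oxygen; one five-membered non-aromatic ring with 1 hetero atom, one six-membered aromatic ring of carbon only) in place of a group of 7 heavy atoms (6 carbon, 1 chlorine; one six-membered aromatic ring of carbon only), on a saturated chain carbon bound to an amine nitrogen and a saturated chain carbon.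

Among the measured compounds shown here, two measured steps offer the only guide, and both are indirect. Methoxy in place of methyl on an aromatic carbon gave no change at the digits printed from compound 1 to compound 2 (within the scatter). Cyclopropyl in place of ethyl on a saturated chain carbon bound to an amine nitrogen gave no change at the digits printed from compound 2 to compound 3 (within the scatter). Neither step touches the 4-chlorophenyl group, so no measurement here tests this exchange directly, and the expectation is correspondingly uncertain. With no movement seen in either step, no change beyond the scatter is expected in this assay, and no direction is favoured. The expected step is no change at the digits printed from compound 2 to compound 4 (within the scatter). For compound 4 the estimate is 3000000 nM, with an expected range from 1500000 nM to 4000000 nM.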

Compound 4, solubility: 3000000 nM
Beside the measured number, compound 4's estimate shows no gap at the digits printed, and the stated range covers the measured number.
By their numbers in this assay, from the lowest: compounds 1, 2, 3 and 4 (each within the scatter of the next).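

In this assay, among the compounds shown here, the exchange at this place gives no change at the digits printed from compound 2 to compound 4 (within the scatter), and this is the first measured change to the 4-chlorophenyl group, since the earlier steps altered other parts of the molecule. The chlorine leaves, and the entering group brings a five-membered non-aromatic ring, an oxygen and one hydrogen-bond acceptor, yet the read-out for compound 4 stays level with that of compound 2. Nothing measured here explains this result.

Going by these compounds, it remains open whether a plain phenyl group or a phenyl ring carrying an amine would also read level at this place on the saturated chain carbon. On these data alone, it is also open whether the same exchange would read alike on compound 1 or compound 3, which differ from compound 2 elsewhere.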